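The source may hold more compounds than are shown below. What is called first, only, known or untested is meant among the compounds shown, and "the series" means these compounds.

Working notes on a small ester series tested in an assay on isolated protein for inhibition of fatty acid synthase (Mus musculus), read by spectrophotometry, using NADPH, with stated times of 30 min and 3 min, in the presence of a further agent that is not named here; on this read-out lower numbers stand for stronger inhibition and higher numbers for weaker inhibition.

Compound 1 `CCCCCCCCCCCC(=O)O[C@H]1C(=O)OCC1(C)C` carries a long-chain acyl ester on the shared core; in this assay compound 1 gives 15200 nM. Compound 2 `CC1(C)COC(=O)[C@@H]1OC(=O)c1ccccc1` replaces that chain with an aromatic ester; in this assay compound 2 gives 23000 nM. Within the data shown here, compound 2 thus stands at the higher of the two numbers measured so far, but its gap to compound 1 lies within the scatter of repeated runs, so the two values cannot be told apart with any confidence and no ordering between them is claimed.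

Compound 3 `CCCCc1ccc(C(=O)O[C@H]2C(=O)OCC2(C)C)cc1` is the next member, not yet measured in this assay. It differs from compound 2 in a single place: butyl in place of hydrogen on an aromatic carbon. Among the measured compounds shown here, no measured pair shows what such a step does here, so the expectation rests on the two values above, which sit close together. With compound 1 giving 15200 nM and compound 2 giving 23000 nM, the step from compound 2 to compound 3 is expected to be small, a 2.1-fold lower number from compound 2 to compound 3 (0.32 log units; beyond the scatter), and may not exceed the scatter. Compound 3 is estimated to give 11000 nM in this assay, with a likely range from 4000 nM to 30000 nM.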

Compound 3, half-maximal inhibitory concentration: 27700 nM
Compound 3: middle estimate off by 2.5-fold (0.40 log units), on the low side, within the range that was stated.
By their numbers in this assay, from the lowest: compounds 1, 2 and 3 (each within the scatter of the next).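

In this assay, butyl in place of hydrogen on an aromatic carbon, para to a large group, amounts to a 1.2-fold higher number from compound 2 to compound 3 (0.08 log units; within the scatter) and so cannot be told apart from no change at all. Among these compounds, this is the first pair that differs in one place, and it shows that this position of the six-membered aromatic ring accepts butyl with no readable effect on the number, which the two earlier values alone could not show. No measurement is available here that bears on the reason for this result.

Still open, going by these compounds, is whether any other group at this aromatic carbon, such as a carboxylic acid, an amine or a longer chain than butyl, would give a step beyond the scatter, or whether the position stays as flat as this one pair suggests. Also open, on these data alone, is whether butyl on another carbon of the same ring would read the same way, since a single step at a single position says nothing about the rest of the ring.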